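Amino to methylamino: cytotoxicity at the assay limit

A few compounds are considered here, and "the series" means these few. Any claim that something is new, unique, unknown or untested is made for them only; others in the source may bear on it.

Working notes on the series. The compounds share the core of compound 1 (`CCC1=C(C(=O)OCC2CCCCC2)C(c2ccc(O)cc2)NC(=O)N1`) and differ in the phenyl group on a saturated ring carbon, as in compound 2 (`CCC1=C(C(=O)OCC2CCCCC2)C(c2cccc([N+](=O)[O-])c2)NC(=O)N1`) and compound 3 (`CCC1=C(C(=O)OCC2CCCCC2)C(c2ccc(N)cc2)NC(=O)N1`).

In an ADME assay on CEMx174 cells (Homo sapiens) for cytotoxicity (on this read-out lower numbers stand for higher toxicity in this test and higher numbers for lower toxicity in this test), compound 1 gives > 10000 nM as a limit of the assay. Compound 2 gives > 10000 nM as a limit too. Compound 3 likewise gives > 10000 nM as a limit and no number. The record so far reads as the limit of > 10000 nM in this assay, at which 3 of the 3 values shown sit, and so holds no measured number for any compound.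

Next comes compound 4 (`CCC1=C(C(=O)OCC2CCCCC2)C(c2ccc(NC)cc2)NC(=O)N1`), set apart from compound 3 by methyl in place of hydrogen on a nitrogen on an aromatic ring and thus a change of amino to methylamino.

Nearest to this change stand a step that the two limits leave unreadable from compound 1 to compound 3 and a step that the two limits leave unreadable from compound 2 to compound 3 while a step that the two limits leave unreadable from compound 1 to compound 2 is the third measured step. None of the three has a size to carry over, and no direction can be drawn from them. In this assay a shift is therefore not expected. The expected step that the limit leaves unreadable from compound 3 to compound 4 is none beyond the scatter.

For compound 4 the estimate is 12000 nM with an expected range from 6000 nM to 25000 nM and a report as a limit is the likeliest outcome.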

Compound 4, half-maximal cytotoxic concentration: > 10000 nM
Compound 4: a limit, no number; the forecaster's own chance of this, stated with the estimate: 85%; the middle value lies beyond the limit too.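

In this assay compound 4 gives > 10000 nM, which is a limit and not a number. Within the data shown here, no step from compound 1, compound 2 or compound 3 to compound 4 can be read: the limit of > 10000 nM in this assay, at which 4 of the 4 values shown sit. The compounds shown leave open whether the phenyl group changes cytotoxicity at all, with no measured number for any of them.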